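A Methyl-for-Bromo Swap on the Benzylidene Arm

The source may report more compounds than this note shows. Statements on the series, on what has been measured and on what is new or still open speak of the compounds shown alone.

Compound 2 `C=CCn1c(=O)/c(=C\c2cccc(Br)c2)[nH]c(=O)/c1=C\c1ccccc1OC` stands with the lowest of the two numbers reported in a functional assay on Huh-7 cells (Homo sapiens) for cytotoxicity, read by CCK-8 assay, with a stated time of 72 h (a lower number here means a stronger inhibitor, a higher number a weaker inhibitor), where compound 2 gives 2300 nM. Its nearest neighbour is compound 1 `C=CCn1c(=O)/c(=C\c2cccc(F)c2)[nH]c(=O)/c1=C\c1ccccc1OC`, which in this assay gives 27200 nM; these two differ only in that compound 2 carries bromo in place of fluoro on an aromatic carbon, a change that gave a 12-fold lower number from compound 1 to compound 2 (1.07 log units; beyond the scatter). The third measured compound, compound 3 `C=CCn1c(=O)/c(=C\c2cccc(Br)c2)[nH]c(=O)/c1=C\c1cccc(Br)c1`, is reported in this assay as "not active" (no number reported), without a number.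

Compound 4 `C=CCn1c(=O)/c(=C\c2ccc(C)cc2)[nH]c(=O)/c1=C\c1ccccc1OC` differs from compound 2 by 4-methylphenyl in place of 3-bromophenyl on a double-bonded chain carbon bound to an aromatic carbon. Going by the values given here, no measured pair shows this exact exchange. Among the compounds with values here, the one step that touches the same aryl group, from compound 1 to compound 2, shows that a change of the halogen alone moved the number by a large amount, so the number in this assay is evidently sensitive to what sits on that ring. Within the data shown here, removing the bromine entirely and placing a methyl at another point is therefore expected to move the number upward, likely by a step of a size comparable to the one seen from compound 1 to compound 2. Compound 4 is thus estimated in this assay at 20000 nM, within 5000 nM to 70000 nM, which corresponds to an expected step of an 8.7-fold higher number from compound 2 to compound 4 (0.94 log units; beyond the scatter).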

Compound 4, half-maximal inhibitory concentration: "not active" (no number reported)
No number was reported for compound 4, and the estimate cannot be compared.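

Compound 4 is reported in this assay as "not active", without a number, so no step can be read from compound 2 to compound 4. The compounds shown leave open how far 4-methylphenyl in place of 3-bromophenyl moves the number on its own. Nothing shown here offers an explanation for this result.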